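The source may report more compounds than this note shows. Statements on the series, on what has been measured and on what is new or still open speak of the compounds shown alone.

Three compounds that share a trifluoromethyl ketone on a thiophene, joined to a small five-membered heteroaromatic core that carries a further aryl group, have been measured in an assay for inhibition of histone deacetylase 4 (Homo sapiens); on this read-out higher numbers stand for weaker inhibition and lower numbers for stronger inhibition. Compound 1 `Cc1ccc(-c2noc(-c3ccc(C(=O)C(F)(F)F)s3)n2)cc1` gives 110 nM, the lowest of the three numbers and therefore the strongest inhibition seen so far. Compound 2 `O=C(c1ccc(-c2nc(-c3cccc(C(F)(F)F)c3)no2)s1)C(F)(F)F` gives 320 nM, and compound 3 `O=C(c1ccc(-c2nnc(-c3ccccc3)o2)s1)C(F)(F)F` gives 420 nM. Both of these gaps to compound 1 lie beyond the usual scatter of repeated measurements, so compound 1 stands out as the most potent of the set.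

Compound 4 `O=C(c1ccc(-c2nc(-c3cccs3)no2)s1)C(F)(F)F` has not yet been measured. It differs from compound 1 in a single place: thiophen-2-yl in place of 4-methylphenyl on an aromatic carbon. Within the data shown here, no pair of measured compounds isolates this exchange, so the size of the step cannot be read from a measured analogue. What can be said is that the measured set contains a six-membered carbon ring with and without a substituent, and that these changes shifted the number by modest amounts. A five-membered ring with one hetero atom is a different kind of replacement, and the expectation is a small move toward weaker inhibition, close to the edge of the scatter, with the step from compound 1 to compound 4 estimated as a 1.8-fold higher number from compound 1 to compound 4 (0.26 log units; within the scatter). On that basis compound 4 is expected to give about 200 nM, with a likely range from 70 nM to 600 nM.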

Compound 4, half-maximal inhibitory concentration: 95 nM
Compound 4: the middle estimate sits 2.1-fold (0.32 log units) above what was measured; the range from low to high includes it.
By their numbers in this assay, from the lowest: compounds 4 and 1 (each within the scatter of the next); then compounds 2 and 3 (each within the scatter of the next).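

In this assay, placing thiophen-2-yl instead of 4-methylphenyl on the aromatic carbon between two ring nitrogen atoms gives a 1.2-fold lower number from compound 1 to compound 4 (0.06 log units; within the scatter), a step that lies within the scatter. Among these compounds, this is the first direct reading of a single exchange at this position, and it shows that a six-membered carbon ring and a five-membered ring containing sulfur cannot be told apart here, although the entering group has fewer heavy atoms and adds a hetero atom. Nothing available explains why the exchange leaves the number essentially unchanged.

Among the compounds shown here, this one pair tests only two aromatic rings at this position, so it cannot show how far the tolerance extends or whether an aromatic ring is needed there at all. Open questions include how the number would respond to a saturated ring such as cyclohexyl, a longer alkyl chain, an amine or a carboxylic acid on the same carbon, and whether a fused aromatic group such as naphthyl would also fit this pattern.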